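The source may report more compounds than this note shows. Statements on the series, on what has been measured and on what is new or still open speak of the compounds shown alone.

Of the compounds shown here, two that share one core have been measured. Compound 1 `O=C(O)Cc1sc(C(Cc2ccccc2)c2ccccc2)nc1-c1ccc(Cl)cc1` gives 56 nM in an in vitro assay on HEK385-7 cells for displacement of a labelled ligand from prostaglandin D2 receptor 2 (Homo sapiens); a lower number here means a stronger inhibitor, a higher number a weaker inhibitor. Among the compounds with values here, compound 2 `O=C(O)Cc1sc(C(c2ccccc2)c2ccc(F)cc2)nc1-c1ccc(Cl)cc1` gives 17 nM in this assay, the lowest of the two numbers so far; the single step that separates it from compound 1 is a 3.3-fold lower number from compound 1 to compound 2 (0.52 log units; beyond the scatter), a modest gain obtained by putting 4-fluorophenyl in place of benzyl on a saturated chain carbon bound to two aromatic carbons.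

Compound 3 `O=C(O)Cc1sc(C(c2ccccc2)c2ccccn2)nc1-c1ccc(Cl)cc1` is the next to be tested. It differs from compound 2 in one place: pyridin-2-yl in place of 4-fluorophenyl on a saturated chain carbon bound to two aromatic carbons. Within the data shown here, no measured step bears directly on this kind of exchange. Among the measured compounds shown here, the only step available, a 3.3-fold lower number from compound 1 to compound 2 (0.52 log units; beyond the scatter), changed a benzyl into an aromatic ring, whereas here one aromatic ring gives way to another, so it offers little guidance on direction or size. Compound 3 is therefore expected to move by about a 1.8-fold higher number from compound 2 to compound 3 (0.25 log units; within the scatter), a step that stays within the scatter. Compound 3 is estimated at 30 nM, with a range from 10 nM to 90 nM.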

Compound 3, half-maximal inhibitory concentration: 810 nM
Estimate against measurement, compound 3: 27-fold (1.43 log units) below; measured number above the stated range.
By their numbers in this assay, from the lowest: compound 2; then compound 1; then compound 3.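

In this assay, the place on the saturated chain carbon bound to two aromatic carbons proves far less tolerant than the first two compounds could show: exchanging one six-membered aromatic ring for another gives a 48-fold higher number from compound 2 to compound 3 (1.68 log units; beyond the scatter), a larger change than replacing benzyl with 4-fluorophenyl produced. Pyridin-2-yl also compares poorly with benzyl, with a 14-fold higher number from compound 1 to compound 3 (1.16 log units; beyond the scatter), so among the three groups seen here it gives the weakest inhibitor, and similarity of ring size and aromatic character clearly does not ensure similar potency. The exchange removes the fluorine and adds a ring nitrogen that counts as a hydrogen-bond acceptor, but no measurement here explains the loss.

The compounds shown leave open whether the loss follows from gaining the ring nitrogen or from losing the fluorine, and a plain phenyl at this place would help to separate those two changes. Pyridin-3-yl and pyridin-4-yl would further show whether any pyridine ring gives such a weak inhibitor here or whether the outcome depends on where the nitrogen lies in the ring.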